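This account rests on a few compounds, and the source may have more. Where it says the series, first, only, none or still open, it means among the compounds named here.

Measured so far in a functional assay on blood for antagonist activity at thromboxane A2 receptor (Homo sapiens); on this read-out lower numbers stand for tighter binding and higher numbers for weaker binding:

- compound 1, `CC(=O)NCc1ccccc1-c1ccc(COC2CC[C@H](N3CCCCCC3)[C@H]2OC/C=C\CCC(=O)O)cc1`: 25.1 nM
- compound 2, `O=C(O)CC/C=C\CO[C@H]1C(OCc2ccc(-c3ccccc3)cc2)CC[C@@H]1N1CCCCC1`: 63.1 nM; 15.9 nM (2 entries)
- compound 3, `O=C(O)CC/C=C\CO[C@H]1[C@@H](OCc2ccc(-c3ccccc3)cc2)CC[C@@H]1N1CCCCC1`: 10 nM; 7.94 nM (2 entries)

Compound 1 has one number in this assay, 25.1 nM, and two further entries that give no single number. For the measured compounds named here, compound 2 and compound 3 each carry several entries (the several entries of compound 2 in this assay, 63.1 nM; 15.9 nM (2 entries), (the several entries of compound 3 in this assay, 10 nM; 7.94 nM (2 entries))); the two compounds differ in how one centre is drawn (the fact that one of compounds 2 and 3 is drawn with a defined configuration and the other without, at the place where they differ), and no step between them is counted here, so only the values themselves are compared: compound 3 sits at lower numbers than compound 1, while the entries of compound 2 spread around compound 1.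

Compound 4, `O=C(O)CC/C=C\CO[C@H]1C(OCc2ccc(-c3ccccc3CO)cc2)CC[C@@H]1N1CCCCCC1`, is not yet measured. It differs from compound 1 by hydroxy in place of acetamido on a saturated chain carbon bound to an aromatic carbon.

Going by the values given here, no measured step of this kind is available. The acetamido group is replaced by a smaller group with the same donor and acceptor count, at the same place; the expected step from compound 1 to compound 4, a 1.3-fold lower number from compound 1 to compound 4 (0.10 log units; within the scatter), is therefore small and within the usual scatter, with no direction claimed. Compound 4 is estimated at 20 nM in this assay, with a range from 7 nM to 60 nM.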

Compound 4, dissociation constant: 3.16 nM
Beside the measured number, compound 4's estimate is 6.3-fold (0.80 log units) above it; the whole stated range lies above it.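

Replacing acetamido with hydroxy on a saturated chain carbon bound to an aromatic carbon gives a 7.9-fold lower number from compound 1 to compound 4 (0.90 log units; beyond the scatter) in this assay. For the compounds shown here, this is the first step read at this place, and it shows that the read-out responds to the group held there. Both groups carry one hydrogen-bond donor and one hydrogen-bond acceptor, so those counts alone do not fix the value, and the group with fewer heavy atoms sits at the lower number.

The compounds shown leave open whether an amine or a methoxy group on the same carbon would read like hydroxy, and whether a longer chain ending in hydroxy would keep the lower number. Going by these compounds alone, the one pair gives no rule beyond these two compounds, and nothing at hand bears on the cause of the step.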